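The source may report more compounds than this note shows. Statements on the series, on what has been measured and on what is new or still open speak of the compounds shown alone.

Measured so far in an ADME assay on MT4 cells (Homo sapiens) for cytotoxicity, read by MTT assay; a higher number here means that more compound is tolerated, a lower number that less compound is tolerated
- Compound 1 `O=C(CSc1nncnc1-c1cccc2ccccc12)Nc1ccccc1[N+](=O)[O-]` gives 142000 nM
- Compound 2 `COC(=O)c1ccc(NC(=O)CSc2nncnc2-c2cccc3ccccc23)c(Br)c1` gives 173000 nM
- Compound 3 `COC(=O)c1ccc(NC(=O)CSc2nncnc2-c2ccccc2Cl)c(Br)c1` gives 59000 nM

Compound 2 and compound 1 lie within the usual scatter of each other, so the two cannot be ranked. Going by the values given here, the gap to the third compound is larger, and it is the one measured step here: a 2.9-fold lower number from compound 2 to compound 3 (0.47 log units; beyond the scatter). That modest step comes from 2-chlorophenyl in place of naphthalen-1-yl on an aromatic carbon, which is a different place from the one at issue now.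

Compound 4 `CC(=O)c1ccc(NC(=O)CSc2nncnc2-c2cccc3ccccc23)c(Br)c1` has not yet been measured. It differs from compound 2 by methyl in place of methoxy on a carbonyl carbon. Put another way, the methoxycarbonyl group of compound 2 becomes an acetyl group in compound 4. Among the compounds with values here, no measured step tests this change directly. The only loose hint is that compound 1 carries no methoxycarbonyl group and gives 142000 nM, although it also differs from compound 2 elsewhere. A change in this assay beyond the scatter is therefore not expected, and neither direction is favoured. The expected size of the change is a 1.2-fold lower number from compound 2 to compound 4 (0.06 log units; within the scatter). For compound 4 the estimated value is 150000 nM, with an expected range from 80000 nM to 280000 nM.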

Compound 4, half-maximal cytotoxic concentration: 133000 nM
Estimate against measurement, compound 4: 1.1-fold (0.05 log units) above; the range from low to high includes it.
By their numbers in this assay, from the lowest: compound 3; then compounds 4, 1 and 2 (each within the scatter of the next).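

In this assay, the change from methoxycarbonyl to acetyl now has its first direct test, and the two compounds cannot be told apart (a 1.3-fold lower number from compound 2 to compound 4 (0.11 log units; within the scatter)). At this carbonyl carbon, then, methyl can stand in place of methoxy, with one heavy atom and one hydrogen-bond acceptor fewer, without a shift beyond the usual scatter. The wider change on the amide-type nitrogen, 4-acetyl-2-bromophenyl in place of 2-nitrophenyl, also stays within the scatter (a 1.1-fold lower number from compound 1 to compound 4 (0.03 log units; within the scatter)), so the earlier loose hint from compound 1 now has a direct comparison behind it.

No measurement is available to explain why these numbers stay so close. Going by these compounds, it remains open whether a carboxylic acid or a primary amide on the same carbonyl carbon would also stay within the scatter, and whether the change to acetyl would read the same on the 2-chlorophenyl compound, compound 3, which sits apart from compound 2 (a 2.9-fold lower number from compound 2 to compound 3 (0.47 log units; beyond the scatter)).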